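From methyl to nitro: what to expect of compound 3

The source may hold more compounds than are shown below. What is called first, only, known or untested is meant among the compounds shown, and "the series" means these compounds.

Compound 1 `CC(C)(O)c1cn(CC(=O)NCc2ccccc2)nn1`: 1600 uM
Compound 2 `Cc1ccccc1-c1cn(CC(=O)NCc2ccccc2)nn1`: 940 uM

In an ADME assay on cells (spleen, Mus musculus, strain C57BL/6) for inhibition, read by flow cytometry and propidium iodide staining, with a stated time of 24 h, at 37 degrees C (a lower number here means that less compound is needed, a higher number that more compound is needed for the effect), compound 2 stands within the scatter of compound 1, so neither ranks ahead. Compound 3 `O=C(Cn1cc(-c2ccccc2[N+](=O)[O-])nn1)NCc1ccccc1` keeps the rest of compound 2 and carries nitro in place of methyl on an aromatic carbon. Within the data shown here, the one measured step (a 1.7-fold lower number from compound 1 to compound 2 (0.23 log units; within the scatter)) exchanged a whole group and stayed small, and no measured compound carries nitro. Only a small move is therefore expected in this assay in no set direction (a 1.0-fold lower number from compound 2 to compound 3 (0.02 log units; within the scatter)). Compound 3 is estimated at 900 uM with 350 uM and 2000 uM as the ends of the expected range.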

Compound 3, concentration for half-maximal effect: "non-toxic" (no number reported)
For compound 3 the study gives words and no number, and the estimate cannot be compared.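

In this assay, among these compounds, compound 3 is reported only in words, as "non-toxic", so no step from compound 2 to compound 3 can be read. No measurement shown bears on this result. The compounds shown leave open how far nitro in place of methyl moves the number.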